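The source may hold more compounds than are shown below. What is called first, only, known or untested is meant among the compounds shown, and "the series" means these compounds.

Measured compounds in a functional assay on PC-3 cells (Homo sapiens) for cytotoxicity, read by MTT assay, with a stated time of 72 h; on this read-out lower numbers stand for stronger inhibition and higher numbers for weaker inhibition:
Compound 1, `CNC(=O)c1cc(Oc2ccc(C(=O)/C=C/c3cccc([N+](=O)[O-])c3)cc2)ccn1`, gives "not determined" (no result reported).
Compound 2, `CNC(=O)c1cc(Oc2ccc(C(=O)/C=C/c3ccccc3)cc2)ccn1`, gives 3170 nM.
Compound 3, `CNC(=O)c1cc(Oc2ccc(C(=O)/C=C/c3ccc(OC)cc3)cc2)ccn1`, gives > 50000 nM, which is a limit of the assay and not a number.

Compound 3 therefore sits at the limit of > 50000 nM in this assay, at which 1 of the 3 values shown sits, so its position on the numbers shown is known only as a bound. Compound 4, `CNC(=O)c1cc(Oc2ccc(C(=O)/C=C/c3ccc([N+](=O)[O-])cc3)cc2)ccn1`, differs from compound 3 in one place: nitro in place of methoxy on an aromatic carbon. For the measured compounds named here, the only measured step that touches this change is an at least 15-fold higher number from compound 2 to compound 3 (1.19 log units; beyond the scatter), which shows that putting methoxy in place of hydrogen on that aromatic carbon lost activity in a large way. Going by the values given here, compound 4 removes that methoxy again, but what nitro adds at the same carbon has no measured counterpart, since compound 1, the other nitro-bearing compound, has no result in this assay. Among the compounds with values here, the expectation is that taking the methoxy away moves compound 4 back toward compound 2, giving a lower number than the bound of compound 3, with wide uncertainty because the step of an at least 15-fold higher number from compound 2 to compound 3 (1.19 log units; beyond the scatter) is the sole guide. Compound 4 is expected to give 6000 nM, within 1500 nM to 40000 nM, an estimated step of an at least 8.3-fold lower number from compound 3 to compound 4 (0.92 log units; beyond the scatter).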

Compound 4, half-maximal inhibitory concentration: 11100 nM
Beside the measured number, compound 4's estimate is 1.9-fold (0.27 log units) below it; measured number inside the range.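

In this assay, the aromatic carbon para to a large group proves able to carry a group other than hydrogen and still give a measurable number: the change from 4-methoxyphenyl to 4-nitrophenyl brings an at least 4.5-fold lower number from compound 3 to compound 4 (0.65 log units; beyond the scatter). Nitro does not fully restore what hydrogen gives at this carbon, however, since the piece now shows a 3.5-fold higher number from compound 2 to compound 4 (0.54 log units; beyond the scatter), so the outcome at this carbon depends on which group is present, with hydrogen giving the lowest number of the three and nitro lying between hydrogen and methoxy. Compound 3 still stands only as a limit of the assay and not as a number, so the true size of the first step stays unknown: the limit of > 50000 nM in this assay, at which 1 of the 4 values shown sits.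

Going by these compounds, compound 1, the other nitro-bearing compound, gives "not determined" (no result reported), so the steps that involve it cannot be read and the effect of moving nitro on that ring remains unknown. Also open, on these data alone, is where an amine, a carboxylic acid or a longer chain at this same carbon would fall relative to hydrogen, nitro and methoxy, and whether any group there can give a lower number than hydrogen does.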